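Closing the Propylamide of Compound 1 into a Piperidine

The compounds below may be only part of what the source reports. "The series", "measured", "known", "first", "only" and "open" are said of these compounds alone.

Compound 1 `CCCNC(=O)Cn1nc(N)c2c(C(F)(F)F)cc(-c3ccccc3)nc21` belongs to a set of three analogues that share one core and differ only in the group on the amide carbonyl. In a functional assay on A549 cells (Homo sapiens) for cytotoxicity, read by MTT assay, with a stated time of 24 h (on this read-out higher numbers stand for weaker inhibition and lower numbers for stronger inhibition), compound 1 gives 16500 nM, the second highest of the three numbers. Compound 2 `Nc1nn(CC(=O)NCCO)c2nc(-c3ccccc3)cc(C(F)(F)F)c12` gives 128000 nM in this assay, and compound 3 `Nc1nn(CC(=O)NCc2ccco2)c2nc(-c3ccccc3)cc(C(F)(F)F)c12` gives 7700 nM. All three steps lie beyond the scatter: a 7.8-fold higher number from compound 1 to compound 2 (0.89 log units; beyond the scatter), a 2.1-fold lower number from compound 1 to compound 3 (0.33 log units; beyond the scatter) and a 17-fold lower number from compound 2 to compound 3 (1.22 log units; beyond the scatter).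

Compound 4 `Nc1nn(CC(=O)N2CCCCC2)c2nc(-c3ccccc3)cc(C(F)(F)F)c12` has not yet been measured. It differs from compound 1 at the carbonyl carbon, (piperidin-1-yl in place of propylamino on a carbonyl carbon), so that propylcarbamoyl becomes (piperidin-1-yl)carbonyl; the propylamino group that leaves carries one hydrogen-bond donor, and the piperidin-1-yl group that enters carries none and brings one six-membered non-aromatic ring with one hetero atom. Within the data shown here, none of the measured steps removes the amide hydrogen, so they bear on this change only loosely: they show that a hydroxy entering raised the number markedly, while a furan-2-yl entering lowered it modestly. Compound 4 adds ring carbon rather than oxygen, so a small step is expected, perhaps within the scatter, and compound 4 is estimated at 12000 nM, from 4000 nM to 40000 nM, which is expected to correspond to a 1.4-fold lower number from compound 1 to compound 4 (0.14 log units; within the scatter).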

Compound 4, half-maximal inhibitory concentration: 1200 nM
Compound 4: the middle estimate sits 10-fold (1.00 log units) above what was measured; measured number below the stated range.
By their numbers in this assay, from the lowest: compound 4; then compound 3; then compound 1; then compound 2.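

In this assay, among these compounds, the group on the carbonyl carbon proves able to move the number much further downward than the earlier compounds showed: piperidin-1-yl in place of propylamino gives a 14-fold lower number from compound 1 to compound 4 (1.14 log units; beyond the scatter), a large step where furan-2-yl on the amide chain had brought only a modest one. The new group also outdoes the two other amide substituents, with a 6.4-fold lower number from compound 3 to compound 4 (0.81 log units; beyond the scatter) and a 110-fold lower number from compound 2 to compound 4 (2.03 log units; beyond the scatter), so that compound 4 holds the lowest number of the four and the series now covers a far wider range at this one position. Compound 4 is also the only one of the four whose group on the carbonyl carbon carries no hydrogen-bond donor, but no measurement at hand explains the drop.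

From the compounds shown here alone, whether the ring or the loss of the amide hydrogen carries the step stays open, as the two change together in compound 4, and a diethylamino group on the same carbonyl carbon would separate them. Also open, going by these compounds, is whether a pyrrolidin-1-yl or morpholin-4-yl group in that place would keep the number as low.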